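Ring methyl step across two cores, whole-animal agonist read-out

The source may hold more compounds than are shown below. What is called first, only, known or untested is meant among the compounds shown, and "the series" means these compounds.

Compound 1 `CC(=O)NCC#CCn1ccnc1` sets the starting point. In a functional assay on the whole organism for agonist activity, with Mus musculus as the target (on this read-out lower numbers stand for an effect already at smaller amounts and higher numbers for an effect only at larger amounts of compound), compound 1 gives only a limit of the assay, > 100 mg/kg. Compound 2 `CC(=O)NCC#CCn1cncc1C` differs from it by methyl in place of hydrogen on an aromatic carbon. In this assay compound 2 also gives only a limit, > 100 mg/kg. The step that the two limits leave unreadable from compound 1 to compound 2 is therefore of unknown size. Compound 3 `O=C1NCCN1CC#CCn1ccnc1` carries a different core; the difference between the two cores is not broken down here. In this assay compound 3 again gives only a limit, > 100 mg/kg. All three values sit together at one point, (the limit of > 100 mg/kg in this assay, at which 3 of the 3 values shown sit).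

Compound 4 `Cc1cncn1CC#CCN1CCNC1=O` is not yet measured in this assay. It differs from compound 3 by methyl in place of hydrogen on an aromatic carbon. The surroundings of the place differ only in wording: the ring atom that bears a large group here, the ring atom that bears a group of 8 heavy atoms between compound 1 and compound 2, so this is the same kind of change. Since the earlier step is unreadable and every value shown sits at the limit, compound 4 is expected to show a step that the limit leaves unreadable from compound 3 to compound 4. Compound 4 is expected to give about 150 mg/kg, between 60 mg/kg and 500 mg/kg, most likely again as a limit.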

Compound 4, dose for half-maximal effect: > 100 mg/kg
Compound 4 was reported as a limit (the forecaster's own chance of this, stated with the estimate: 85%); the middle value is on the limit's open side.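

No step can be read from compound 3 to compound 4 in this assay; both compounds are reported only as limits, so the methyl in place of hydrogen has no readable size here: the limit of > 100 mg/kg in this assay, at which 4 of the 4 values shown sit.

The compounds shown leave open how large the methyl step is on either core and whether the core itself affects this read-out.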